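The compounds below may be only part of what the source reports. "The series", "measured", "known", "first", "only" and "open" are said of these compounds alone.

For the measured compounds named here, in a functional assay on MDA-MB-468 cells (Homo sapiens) for cytotoxicity, read by sulforhodamine B assay, with a stated time of 48 h, in the presence of a further agent that is not named here (a higher number here means a weaker inhibitor of growth, a lower number a stronger inhibitor of growth), compound 2 `CN(C)CCNc1ccnc2cc(F)ccc12` gives 4870 nM, the highest of the two numbers so far; compound 1 `CN(C)CCNc1ccnc2cc(Cl)ccc12` gives 3430 nM, and the step of a 1.4-fold higher number from compound 1 to compound 2 (0.15 log units; within the scatter) lies within the scatter. Compound 3 `COc1ccc2c(NCCN(C)C)ccnc2c1` differs from compound 2 by methoxy in place of fluoro on an aromatic carbon. Going by the values given here, the only measured step, a 1.4-fold higher number from compound 1 to compound 2 (0.15 log units; within the scatter), trades one halogen for another and barely moves the number; no measured step exchanges a halogen for methoxy, so nothing bears directly on this change. For compound 3 the expected step is a 1.1-fold higher number from compound 2 to compound 3 (0.05 log units; within the scatter), not beyond the scatter. Compound 3 is therefore estimated at 5500 nM, between 2000 nM and 15000 nM.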

Compound 3, concentration for 50% growth inhibition: 5850 nM
Beside the measured number, compound 3's estimate is 1.1-fold (0.03 log units) below it; the range from low to high includes it.
By their numbers in this assay, from the lowest: compounds 1, 2 and 3 (each within the scatter of the next).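

Read in this assay the methoxy group in place of fluoro gives a 1.2-fold higher number from compound 2 to compound 3 (0.08 log units; within the scatter) and in place of chloro gives a 1.7-fold higher number from compound 1 to compound 3 (0.23 log units; within the scatter) and so neither change leaves the scatter. The earlier pair compared only two halogens. This position on the aromatic carbon now also takes a group with two heavy atoms and a hydrogen-bond acceptor, with no step beyond the scatter among the three compounds.

From the compounds shown here alone, whether an amine, a carboxylic acid or a longer chain such as ethoxy at this position would also stay within the scatter remains open. Nothing available here explains these numbers.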